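The source may hold more compounds than are shown below. What is called first, only, known or untested is meant among the compounds shown, and "the series" means these compounds.

Measured so far in an ADME assay on L02 cells (Homo sapiens) for cytotoxicity, read by MTT assay, with a stated time of 48 h; on this read-out lower numbers stand for stronger inhibition and higher numbers for weaker inhibition:
compound 1 `O=C1CSC(=O)N1C[C@H]1CN(c2ccc(-n3cc(-c4ccccn4)cn3)c(F)c2)C(=O)O1` gives > 400 ug/mL, which is a limit of the assay.
compound 2 `CN(C)S(=O)(=O)NC[C@H]1CN(c2ccc(-n3cc(-c4ccccn4)cn3)c(F)c2)C(=O)O1` gives 158 ug/mL.

Within the data shown here, compound 2 carries the only numerical value in this assay; the other entry stands at the limit of > 400 ug/mL in this assay, at which 1 of the 2 values shown sits. Compound 3 `COC(=O)NC[C@H]1CN(c2ccc(-n3cc(-c4ccccn4)cn3)c(F)c2)C(=O)O1` differs from compound 2 by methoxycarbonyl in place of dimethylsulfamoyl on an amine nitrogen. Among the measured compounds shown here, the single measured step, an at least 2.5-fold lower number from compound 1 to compound 2 (0.40 log units; beyond the scatter), concerns a different exchange on that chain and shows that such an exchange shifts the number at least modestly. For compound 3 a modest shift back toward the limit is expected, a 1.6-fold higher number from compound 2 to compound 3 (0.20 log units; within the scatter). The estimate for compound 3 is 250 ug/mL, between 100 ug/mL and 400 ug/mL.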

Compound 3, half-maximal inhibitory concentration: 71 ug/mL
The estimate for compound 3 lay 3.5-fold (0.55 log units) above the measured number, outside the stated range (below it).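

In this assay the group on the amine nitrogen of the chain still moves the number when the (...)amino link stays in place: methoxycarbonyl in place of dimethylsulfamoyl gives a shift toward stronger inhibition, not back toward the limit (a 2.2-fold lower number from compound 2 to compound 3 (0.35 log units; beyond the scatter)). Measured against 2,4-dioxo-1,3-thiazolidin-3-yl on the same chain, the gap is wider (an at least 5.6-fold lower number from compound 1 to compound 3 (0.75 log units; beyond the scatter)). Compound 1 stands at a limit of the assay, not at a number: the limit of > 400 ug/mL in this assay, at which 1 of the 3 values shown sits.

As far as these compounds go, what a free amine, an acetyl group or an ethoxycarbonyl group on that nitrogen would give stays open. From the compounds shown here alone, whether any group on that chain goes lower than compound 3 also stays open.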